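Methyl for Fluoro on the Triazole Aryl Ring

A few compounds are considered here, and "the series" means these few. Any claim that something is new, unique, unknown or untested is made for them only; others in the source may bear on it.

Compound 1 `C=C1C[C@]23C[C@@]1(O)CC[C@H]2c1ccc(OS(=O)(=O)c2ccc(C)cc2)c(C)c1[C@@H]3Cn1cc(-c2ccc(C)cc2)nn1`: in a functional assay on SW480 cells (Homo sapiens) for cytotoxicity, read by MTT assay, with a stated time of 4 days (on this read-out higher numbers stand for weaker inhibition and lower numbers for stronger inhibition), compound 1 gives only a limit, > 20000 nM.
Compound 2 `C=C1C[C@]23C[C@@]1(O)CC[C@H]2c1ccc(OS(=O)(=O)c2ccc(C)cc2)c(C)c1[C@@H]3Cn1cc(-c2ccc(F)cc2)nn1`: in this assay compound 2 likewise gives only a limit, > 20000 nM.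
Compound 3 `C=C1C(=O)[C@]23C[C@@]1(O)CC[C@H]2c1ccc(OS(=O)(=O)c2ccc(C)cc2)c(C)c1[C@@H]3Cn1cc(-c2ccc(F)cc2)nn1`: in this assay compound 3 gives 1630 nM.

Compound 1 and compound 2 differ by one change, (methyl in place of fluoro on an aromatic carbon). Its step, a step that the two limits leave unreadable from compound 2 to compound 1, cannot be sized because of the limit of > 20000 nM in this assay, at which 2 of the 3 values shown sit. Compound 3 has a different core from compound 2; that difference is not broken down here. Compound 4 `C=C1C(=O)[C@]23C[C@@]1(O)CC[C@H]2c1ccc(OS(=O)(=O)c2ccc(C)cc2)c(C)c1[C@@H]3Cn1cc(-c2ccc(C)cc2)nn1` carries the same change made on compound 3: methyl in place of fluoro on an aromatic carbon. The earlier example of this change gives no readable size, so the expectation rests on compound 3 alone and its value of 1630 nM, with compound 4 expected close to it. The expected step is a 1.5-fold higher number from compound 3 to compound 4 (0.19 log units; within the scatter). Compound 4 is estimated at 2500 nM, likely between 800 nM and 8000 nM.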

Compound 4, half-maximal inhibitory concentration: 1460 nM
Compound 4: middle estimate off by 1.7-fold (0.23 log units), on the high side; low and high end bracket the measured number.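

Methyl in place of fluoro on the aryl ring gives a 1.1-fold lower number from compound 3 to compound 4 (0.05 log units; within the scatter) in this assay, so on this core the change has no size that stands out from the usual scatter. On the core of compound 1 the same change cannot be read, because the values there are limits and not numbers: the limit of > 20000 nM in this assay, at which 2 of the 4 values shown sit. The change therefore has one readable size, on one core, which shows that it is tolerated there but not whether it would behave the same way on the other core.

Still open, from the compounds shown here alone, is what an amine, a carboxylic acid or a longer chain would do in place of the fluoro on that aromatic carbon. Only these two small groups are shown there, so how far this position responds to change remains unknown.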